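Dropping the methoxy from compound 1: toxicity toward Vero cells

This account rests on a few compounds, and the source may have more. Where it says the series, first, only, none or still open, it means among the compounds named here.

Of the compounds shown here, three sharing one core have been measured in an ADME assay on Vero cells (Chlorocebus sabaeus) for cytotoxicity, read by MTT assay, with a stated time of 72 h; on this read-out lower numbers stand for higher toxicity in this test and higher numbers for lower toxicity in this test. Compound 1 `CCN(CC)CC(O)CN(Cc1ccc(OC)cc1)Cc1cc2ccccc2nc1OC` gives 727000 nM. Compound 2 `COc1ccc(CN(Cc2cc3ccccc3nc2OC)CC(O)CN2CCCC2)cc1` gives 664000 nM, and compound 3 `COc1nc2ccccc2cc1CN(Cc1ccc(C)cc1)CC(O)CN1CCCC1` gives 1110000 nM. Among these three numbers compound 1 stands second highest; its nearest neighbour is compound 2 and its furthest is compound 3, and neither gap lies beyond the scatter.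

Two single changes link the measured compounds. The step of a 1.1-fold lower number from compound 1 to compound 2 (0.04 log units; within the scatter) exchanges the amine at the end of the saturated chain and stays within the scatter. The step of a 1.7-fold higher number from compound 2 to compound 3 (0.22 log units; within the scatter) swaps the substituent on the benzyl ring and also stays within the scatter.

Compound 4 `CCN(CC)CC(O)CN(Cc1ccccc1)Cc1cc2ccccc2nc1OC` is not yet measured. It differs from compound 1 by hydrogen in place of methoxy on an aromatic carbon; cut one bond further out, the change reads 4-methoxybenzyl to benzyl. The step from compound 2 to compound 3 is the one that bears on this, since it also alters the group on that aromatic carbon, and it produced nothing beyond the scatter. Compound 4 is therefore expected to show a 1.0-fold higher number from compound 1 to compound 4 (0.01 log units; within the scatter), no more than the scatter allows. The estimated value for compound 4 in this assay is 750000 nM, with a range from 350000 nM to 1600000 nM.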

Compound 4, half-maximal cytotoxic concentration: 613000 nM
Compound 4: middle estimate off by 1.2-fold (0.09 log units), on the high side; the range from low to high includes it.
By their numbers in this assay, from the lowest: compounds 4, 2, 1 and 3 (each within the scatter of the next).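

Compound 4 takes the methoxy off the aromatic carbon altogether, para to a large group, rather than exchanging it for another group, and in this assay the step of a 1.2-fold lower number from compound 1 to compound 4 (0.07 log units; within the scatter) stays within the scatter. Together with the earlier step of a 1.7-fold higher number from compound 2 to compound 3 (0.22 log units; within the scatter), which also stays within the scatter, this gives two changes at this aromatic carbon, one beside a diethylamino end of the chain and one beside a pyrrolidin-1-yl end, and neither separates the compounds on this read-out. With methoxy, methyl and hydrogen all seen at this carbon, the loss of the two heavy atoms and the one hydrogen-bond acceptor of methoxy leaves the number within the scatter, and nothing in the data offers an explanation for this.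

Going by these compounds, what remains open is whether a charged or larger group on the same aromatic carbon, such as a carboxylic acid, a primary amine or a trifluoromethyl group, would also stay within the scatter. Equally open, on these data alone, is whether a longer chain or a piperidine at the end of the saturated chain would give a number outside the scatter of these four compounds.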